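Methyl for Chloro on the Phenyl of Compound 2

The source may hold more compounds than are shown below. What is called first, only, known or untested is meant among the compounds shown, and "the series" means these compounds.

In an ADME assay on L02 cells (Homo sapiens) for antiproliferative activity, read by MTT assay, with a stated time of 48 h; a higher number here means a weaker inhibitor, a lower number a stronger inhibitor:
Compound 1, `N#CC1=C(N)Oc2c(N)cc3nc4ccccc4nc3c2C12C(=O)N(Cc1cnnn1-c1ccccc1Br)c1ccccc12`: 29200 nM
Compound 2, `N#CC1=C(N)Oc2c(N)cc3nc4ccccc4nc3c2C12C(=O)N(Cc1cnnn1-c1cc(Cl)ccc1Cl)c1ccccc12`: > 50000 nM

The reading for compound 2 is a limit rather than a number, (the limit of > 50000 nM in this assay, at which 1 of the 2 values shown sits). The step of an at least 1.7-fold higher number from compound 1 to compound 2 (0.23 log units; that floor lies within the scatter) is thus only a floor. Compound 3, `Cc1ccc(Cl)cc1-n1nncc1CN1C(=O)C2(C(C#N)=C(N)Oc3c(N)cc4nc5ccccc5nc4c32)c2ccccc21`, differs from compound 2 by methyl in place of chloro on an aromatic carbon. Going by the values given here, no measured step exchanges methyl for chloro; the only step on this phenyl, the one from compound 1 to compound 2, has a floor within the scatter. With that alone to go on, the expected step is a number no higher from compound 2 to compound 3 (the limit leaves the size open), within the scatter, and another limit is a fair possibility. Compound 3 is estimated at 50000 nM, ranging from 20000 nM to 120000 nM.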

Compound 3, half-maximal inhibitory concentration: > 50000 nM
Compound 3: a limit, no number; the forecaster's own chance of this, stated with the estimate: 55%; the middle value sits exactly at the limit.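

In this assay compound 3 reads > 50000 nM, which is again a limit, so the exchange of chloro for methyl cannot be read. Against the 2-bromophenyl of compound 1, the 5-chloro-2-methylphenyl group gives an at least 1.7-fold higher number from compound 1 to compound 3 (0.23 log units; that floor lies within the scatter), which is only a floor, as the earlier step was. A second substitution pattern on this phenyl now sits at the limit: the limit of > 50000 nM in this assay, at which 2 of the 3 values shown sit.

From the compounds shown here alone, what an amine or a carboxylic acid at this place would read in this assay stays open. Any real difference between compound 2 and compound 3 also stays open.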